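A few compounds are considered here, and "the series" means these few. Any claim that something is new, unique, unknown or untested is made for them only; others in the source may bear on it.

Measured compounds in an ADME assay on microsomes from liver (Homo sapiens); on this read-out lower numbers stand for lower hepatic extraction and higher numbers for higher hepatic extraction:
- compound 1, `O=C(Nc1cccnc1)Nc1cc(F)cc(Oc2cccnc2)c1`, "not determined" (no result reported)
- compound 2, `CC(=O)N1CCC[C@@H](Oc2cc(F)cc(NC(=O)Nc3cccnc3)c2)C1`, 0.5
- compound 3, `CC(=O)N1CCC[C@@H](Oc2cc(F)cc(NC(=O)Nc3ccc(C)nc3)c2)C1`, 0.6

Compound 2 gives the lowest of the two numbers in this assay. Its nearest neighbour is compound 3, and the step a number 0.10 higher from compound 2 to compound 3 (within the scatter) stays within the scatter, so the two values are not told apart. Compound 1 carries no number in this assay and contributes nothing to the comparison.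

Compound 4, `COC(=O)N1CCC[C@@H](Oc2cc(F)cc(NC(=O)Nc3cccnc3)c2)C1`, is not yet measured. It differs from compound 2 in one place: methoxy in place of methyl on a carbonyl carbon. Read one bond further out, the change is acetyl to methoxycarbonyl.

Going by the values given here, of the measured steps only the one from compound 2 to compound 3 exists, and it concerns a methyl in place of hydrogen on an aromatic carbon, a change of a different kind at a different place. Among the compounds with values here, no measured pair shows methoxy in place of methyl on a carbonyl carbon, so no step in this assay bears directly on compound 4. Within the data shown here, with the single measured step within the scatter and no direct precedent, no step beyond the scatter is expected from compound 2 to compound 4; the expected step is no change at the digits printed from compound 2 to compound 4 (within the scatter).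

Compound 4 is therefore estimated at 0.5 in this assay, with a range from 0.3 to 0.7.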

Compound 4, hepatic extraction ratio: 0.5
Beside the measured number, compound 4's estimate shows no gap at the digits printed; low and high end bracket the measured number.
By their numbers in this assay, from the lowest: compounds 2, 4 and 3 (each within the scatter of the next).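

Compounds 2 and 3 speak only to methyl in place of hydrogen on an aromatic carbon, and they leave the carbonyl carbon whose other neighbour is the amide-type nitrogen in a ring untested. In this assay, methoxy in place of methyl on that carbonyl carbon, read one bond further out as acetyl to methoxycarbonyl, gives no change at the digits printed from compound 2 to compound 4 (within the scatter), so at this position the swap from acetyl to methoxycarbonyl does not separate the two compounds on this read-out. This rests on a single pair, and nothing among the data shown explains the result.

Going by these compounds, still open in this assay is whether a dimethylamino group, or a longer chain such as ethoxy or tert-butoxy, in place of methoxy on this carbonyl carbon would give a step beyond the scatter. Also open, on these data alone, is whether the methyl on an aromatic carbon that separates compound 3 from compound 2 would behave the same way when combined with methoxycarbonyl, and any step involving compound 1 cannot be read.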